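The source may hold more compounds than are shown below. What is called first, only, known or untested is meant among the compounds shown, and "the series" means these compounds.

Measured compounds in a physicochemical assay for lipophilicity, read by HPLC, measured as octanol-water partition; on this read-out higher numbers stand for higher lipophilicity and lower numbers for lower lipophilicity:
compound 1 `O=C(OC[C@H]1CN(c2ccc(-n3cc(-c4ccccn4)cn3)c(F)c2)C(=O)O1)c1ccccc1` gives 4.21
compound 2 `O=C1O[C@@H](Cn2ccnn2)CN1c1ccc(-n2cc(-c3ccccn3)cn2)c(F)c1` gives 2
compound 3 `CCC(=O)NC[C@H]1CN(c2ccc(-n3cc(-c4ccccn4)cn3)c(F)c2)C(=O)O1` gives 2.2

Compound 3 stands second highest of the three numbers in this assay. Its nearest neighbour is compound 2, a number 0.20 log units higher from compound 2 to compound 3 (within the scatter), so the two cannot be told apart. The one large gap in the set runs to compound 1: a number 2.01 log units lower from compound 1 to compound 3 (beyond the scatter), and likewise a number 2.21 log units lower from compound 1 to compound 2 (beyond the scatter). Both large steps exchange the benzoyloxy group on the saturated chain carbon bound to a saturated ring carbon; neither touches a carbonyl carbon.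

Compound 4 `COC(=O)NC[C@H]1CN(c2ccc(-n3cc(-c4ccccn4)cn3)c(F)c2)C(=O)O1` differs from compound 3 in that place: methoxy in place of ethyl on a carbonyl carbon, or, read one bond further out, propanoylamino to (methoxycarbonyl)amino. Within the data shown here, no measured step in this assay bears directly on it. Since the groups that enter and leave are of the same size and the change sits on the carbonyl carbon of the amide-type nitrogen, only a small move is expected, towards the lower side given the acceptor that enters, and the step is estimated at a number 0.40 log units lower from compound 3 to compound 4 (beyond the scatter). The expected value for compound 4 is 1.8, with a range from 1.3 to 2.3.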

Compound 4, partition coefficient: 2.03
The estimate for compound 4 lay 0.23 log units below the measured number, and the stated range covers the measured number.
By their numbers in this assay, from the lowest: compounds 2, 4 and 3 (each within the scatter of the next); then compound 1.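

In this assay, methoxy in place of ethyl on the carbonyl carbon gives a step that stays small (a number 0.17 log units lower from compound 3 to compound 4 (within the scatter)), so adding the hydrogen-bond acceptor at this place leaves the number within the scatter. On the saturated chain carbon, (methoxycarbonyl)amino cannot be separated from 1H-1,2,3-triazol-1-yl (a number 0.03 log units higher from compound 2 to compound 4 (within the scatter)), whereas the gap from benzoyloxy remains large (a number 2.18 log units lower from compound 1 to compound 4 (beyond the scatter)), which places compound 2, compound 3 and compound 4 together, with compound 1 as the exception. Nothing available explains either the small or the large steps.

As far as these compounds go, it remains open whether benzoylamino would stay with these three compounds in this assay or move towards compound 1. From the compounds shown here alone, how a primary amine or a carboxylic acid at this chain carbon would read is also open.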